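This account rests on a few compounds, and the source may have more. Where it says the series, first, only, none or still open, it means among the compounds named here.

Compound 1 `Cc1noc(-c2nc(C)c3c(c2N)C(=O)N(Cc2ccccc2)C3=O)n1`: < 5000 nM (a limit of the assay, not a number)
Compound 2 `Cc1noc(-c2nc(C)c3c(c2N)C(=O)N(CC2CCNCC2)C3=O)n1`: 160000 nM

For the measured compounds named here, in a physicochemical assay for solubility, using the shake flask method, in simulated intestinal fluid, measured as kinetic solubility, with a stated time of 2 h, at 25 degrees C, at pH 6.5 (a lower number here means a less soluble compound, a higher number a more soluble compound), compound 2 gives 160000 nM, the only actual number so far. Compound 1 gives a limit only: the limit of < 5000 nM in this assay, at which 1 of the 2 values shown sits.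

Compound 3 `Cc1noc(-c2nc(C)c3c(c2N)C(=O)N(CC2CCOCC2)C3=O)n1` has not yet been measured. It carries oxan-4-yl in place of piperidin-4-yl on a saturated chain carbon bound to an amide-type nitrogen in a ring.

Going by the values given here, one measured step bears on this change. It acts at the same place, where piperidin-4-yl replaced phenyl, and it is large: an at least 32-fold higher number from compound 1 to compound 2 (1.50 log units; beyond the scatter). As far as these compounds go, because one end of that step is a limit, its full size is unknown. Compound 3 gives up the piperidin-4-yl group that this step brought in, but it keeps a six-membered non-aromatic ring with 1 hetero atom, so only part of that step is expected to be reversed. A clear fall in this assay, beyond the scatter, is therefore expected. The estimated change is a 4.6-fold lower number from compound 2 to compound 3 (0.66 log units; beyond the scatter). For compound 3 the estimated value is 35000 nM, with an expected range of 8000 nM to 130000 nM.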

Compound 3, solubility: 5700 nM
The estimate for compound 3 lay 6.1-fold (0.79 log units) above the measured number, and the stated range ends above it.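

At this place, on a saturated chain carbon bound to an amide-type nitrogen in a ring, keeping a six-membered non-aromatic ring with 1 hetero atom does not keep the high number of compound 2 in this assay: oxan-4-yl in place of piperidin-4-yl gives a 28-fold lower number from compound 2 to compound 3 (1.45 log units; beyond the scatter). The two groups match in heavy atom count and differ in carrying nitrogen or oxygen, with 1 hydrogen-bond donor against 0, so among these compounds the high number goes with piperidin-4-yl and not with a saturated ring as such. Against phenyl, oxan-4-yl gives only a floor, an at least 1.1-fold higher number from compound 1 to compound 3 (0.05 log units; that floor lies within the scatter), and the true size of this step cannot be read because compound 1 stands at a limit of the assay, not at a number: the limit of < 5000 nM in this assay, at which 1 of the 3 values shown sits.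

The compounds shown leave open whether another amine at this place, such as a methylated piperidine or an open-chain aminoalkyl group, would hold the number of compound 2. They also leave open what a carboxylic acid or a longer chain carrying the piperidin-4-yl group would give in this assay.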